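The source may report more compounds than this note shows. Statements on the series, on what has been measured and on what is new or still open speak of the compounds shown alone.

Compound 1, with the structure `Cc1cccn2cc(-c3nnc(-c4ccc(Br)cc4)o3)nc12`, is the starting point. In a functional assay on A549 cells (Homo sapiens) for antiproliferative activity, read by MTT assay, with a stated time of 48 h (on this read-out higher numbers stand for weaker inhibition and lower numbers for stronger inhibition), compound 1 gives 34700 nM. Compound 2, with the structure `Cc1cccn2cc(-c3nnc(-c4ccc(N(C)C)cc4)o3)nc12`, differs from it in one place: dimethylamino in place of bromo on an aromatic carbon. In this assay compound 2 gives 12300 nM, which is a 2.8-fold lower number from compound 1 to compound 2 (0.45 log units; beyond the scatter).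

Compound 3, with the structure `Cc1cc(Br)c2nc(-c3nnc(-c4ccc(Br)cc4)o3)cn2c1`, carries a different core; how that core differs from the core of compound 1 is not broken down here. In this assay compound 3 gives 23400 nM. Set beside the values of compound 1 and compound 2, this number lies within the usual scatter of both, so no ordering among the three can be read from it.

Compound 4, with the structure `Cc1cc(Br)c2nc(-c3nnc(-c4ccc(N(C)C)cc4)o3)cn2c1`, is not yet measured. It stands to compound 3 as compound 2 stands to compound 1: dimethylamino in place of bromo on an aromatic carbon. The surroundings of the change are described in the same words in both pairs, so it is the same change on a different core. For compound 4 the expected step is a 2.8-fold lower number from compound 3 to compound 4 (0.44 log units; beyond the scatter), because the same change once gave a 2.8-fold lower number from compound 1 to compound 2 (0.45 log units; beyond the scatter). Compound 4 is therefore estimated at 8500 nM, with a likely range from 3500 nM to 20000 nM.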

Compound 4, half-maximal inhibitory concentration: 10800 nM
Estimate against measurement, compound 4: 1.3-fold (0.10 log units) below; low and high end bracket the measured number.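

Dimethylamino in place of bromo gives a 2.2-fold lower number from compound 3 to compound 4 (0.34 log units; beyond the scatter) in this assay and so lowers the number on the second core as it did on the first. The size of the step also carries over, as far as these pairs can tell: the same change on two cores in this assay, a 2.8-fold lower number (0.45 log units; beyond the scatter) from compound 1 to compound 2 and a 2.2-fold lower number (0.34 log units; beyond the scatter) from compound 3 to compound 4, 1.3-fold (0.11 log units) apart, within the scatter of two such steps

Among the compounds shown here, this rests on only two pairs, each a modest step, so it does not show that the change would act alike on a third core, and it does not explain why the number falls.

The compounds shown leave open whether another group on the same aromatic carbon, such as a primary amine, a methoxy group or a carboxylic acid, would lower the number further than dimethylamino does. They also leave open what would happen if the bromo that stays on the core of compound 4 were replaced by another group, such as a nitrile.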